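The compounds below may be only part of what the source reports. "The series", "measured", "known", "first", "only" and "open" are said of these compounds alone.

Compound 1 `CCOC(=O)c1nn(-c2ccccc2)c(-c2ccc(OC)cc2)c1CNC(C)(C)C`: 116000 nM; 244000 nM (2 entries)
Compound 2 `CCOC(=O)c1nn(-c2ccc(Cl)cc2)c(-c2ccccc2)c1CNC(C)(C)C`: > 608000 nM; > 559000 nM (2 entries) (a limit, not a number)
Compound 3 `CC(C)(C)NCc1c(C(=O)O)nn(-c2ccccc2)c1-c1ccc(Cl)cc1`: > 652000 nM (a limit, not a number)

These results come from a functional assay on MCF7 cells (Homo sapiens) for inhibition, read by sulforhodamine B assay, with a stated time of 48 h; on this read-out higher numbers stand for weaker inhibition of growth and lower numbers for stronger inhibition of growth. Compound 3 has no single number here, only the limit > 652000 nM. Compound 4 `CC(C)(C)NCc1c(C(=O)O)nn(-c2ccccc2)c1-c1ccc([N+](=O)[O-])cc1` carries nitro in place of chloro on an aromatic carbon, para to a large group: nitro in place of chloro on an aromatic carbon. Within the data shown here, no two measured compounds differ in one place alone, so the data do not show the size of this kind of change. Without such a guide, no step beyond the scatter is expected in this assay, and no direction can be favoured. The estimated step of a number no higher from compound 3 to compound 4 (the limit leaves the size open) reflects that expectation. For compound 4 the expected value is 650000 nM, with an estimated range of 250000 nM to 1500000 nM.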

Compound 4, concentration for 50% growth inhibition: > 634000 nM
Compound 4: a limit, no number; the forecaster's own chance of this, stated with the estimate: 75%; the middle value is on the limit's open side.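

Compound 3 and compound 4 each give only a limit, not a number, in this assay, so no step can be read between them. The compounds shown leave open whether nitro in place of chloro changes growth inhibition at all, and in which direction.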